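The source may report more compounds than this note shows. Statements on the series, on what has been measured and on what is new or still open speak of the compounds shown alone.

Measured in an assay on HEK293 cells for positive allosteric modulation of metabotropic glutamate receptor 2 (Rattus norvegicus), read by thallium flux, with a stated time of 2.5 min; a higher number here means that more compound is needed for the effect, a lower number that less compound is needed:
Compound 1 `Cc1c(OCCCCOc2ccc(C(=O)O)cc2Cl)ccc(C(=O)CC2CCCC2)c1O` gives 237 nM.
Compound 2 `Cc1c(OCCCCOc2ccc(F)c(C(=O)O)c2)ccc(C(=O)CC2CCCC2)c1O` gives 699 nM.
Compound 3 `Cc1c(OCCCCOCOc2ccc(C(=O)O)cc2)ccc(C(=O)CC2CCCC2)c1O` gives 228 nM.

Compound 2 stands highest of the three numbers: the step of a 2.9-fold higher number from compound 1 to compound 2 (0.47 log units; beyond the scatter) and the step of a 3.1-fold lower number from compound 2 to compound 3 (0.49 log units; beyond the scatter) both lie beyond the scatter, while a 1.0-fold lower number from compound 1 to compound 3 (0.02 log units; within the scatter) stays within it. All three measured steps vary the group on the oxygen on a saturated carbon; none of them touches the carbonyl side of the shared core.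

Compound 4 `Cc1c(OCCCCOc2ccc(F)c(C(=O)O)c2)ccc(C(=O)CC(C)(C)C)c1O` differs from compound 2 on that other side: tert-butyl in place of cyclopentyl on a saturated chain carbon bound to a carbonyl carbon. Among the measured compounds shown here, no measured step bears on this change, so these numbers give no basis for a direction. Expected is therefore no step beyond the scatter, a 1.0-fold higher number from compound 2 to compound 4 (0.00 log units; within the scatter), with the range kept wider than usual since the change has no precedent in the series. For compound 4 the expected value in this assay is 700 nM, with a range from 280 nM to 1750 nM.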

Compound 4, half-maximal effective concentration: 208 nM
The estimate for compound 4 lay 3.4-fold (0.53 log units) above the measured number; the measured number lies below the stated range.
By their numbers in this assay, from the lowest: compounds 4, 3 and 1 (each within the scatter of the next); then compound 2.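

The carbonyl side of the shared core responds in this assay: tert-butyl in place of cyclopentyl on a saturated chain carbon bound to a carbonyl carbon gives a 3.4-fold lower number from compound 2 to compound 4 (0.53 log units; beyond the scatter) as the first step read at this position. For this pair, the lower number comes with the group that has no ring, so the five-membered non-aromatic ring of cyclopentyl is not needed here for the effect to be reached with less compound. No measured property of these groups accounts for the step.

Open, from the compounds shown here alone, is whether the same change carries over to compound 1 or compound 3, since tert-butyl appears here only with the 3-carboxy-4-fluorophenyl group of compound 4. Also open, going by these compounds, is how this position answers to other groups, such as isopropyl, cyclohexyl or a longer chain.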